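Dimethylamino compounds: swapping naphthalen-2-yl for 4-methoxyphenyl

The source may hold more compounds than are shown below. What is called first, only, known or untested is meant among the compounds shown, and "the series" means these compounds.

Values in a functional assay on A549 cells (Homo sapiens) for antiproliferative activity, read by MTT assay, with a stated time of 72 h; a lower number here means a stronger inhibitor, a higher number a weaker inhibitor:
- compound 1 `CNc1nc(-c2cc(OC)c(OC)c(OC)c2)c(-c2ccc3ccccc3c2)s1`: 151 nM
- compound 2 `CCOc1ccc(-c2sc(NC)nc2-c2cc(OC)c(OC)c(OC)c2)cc1`: 38.6 nM
- compound 3 `COc1cc(-c2nc(N(C)C)sc2-c2ccc3ccccc3c2)cc(OC)c1OC`: 2900 nM

Compound 3 has the highest number of the three, which makes it the weakest inhibitor so far. Within the data shown here, the only measured step is a 19-fold higher number from compound 1 to compound 3 (1.28 log units; beyond the scatter), for methyl in place of hydrogen on a nitrogen. That step is large, but it lies at a different place from the change considered here.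

Compound 4 `COc1ccc(-c2sc(N(C)C)nc2-c2cc(OC)c(OC)c(OC)c2)cc1` keeps the dimethylamino group of compound 3 and carries 4-methoxyphenyl in place of naphthalen-2-yl on an aromatic carbon.

Among the measured compounds shown here, no measured step covers this swap directly. The nearest guide is a pair of values: compound 1 gives 151 nM, while compound 2, which has no naphthalen-2-yl and no 4-methoxyphenyl, gives 38.6 nM. A moderate move towards a lower number is therefore expected in this assay, estimated as a 4.1-fold lower number from compound 3 to compound 4 (0.62 log units; beyond the scatter).

For compound 4 the estimated value is 700 nM, with an expected range of 170 nM to 2900 nM.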

Compound 4, half-maximal inhibitory concentration: > 10000 nM
Compound 4 gave a limit, no number; the forecaster's own chance of this, stated with the estimate: 3%; middle value at least 14-fold (1.15 log units) away from the limit.
By their numbers in this assay, from the lowest: compound 2; then compound 1; then compound 3. At a limit, above all of these: compound 4.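

With the dimethylamino group in place, 4-methoxyphenyl does not restore activity at this aromatic carbon: in this assay compound 4 gives only a limit, > 10000 nM, not a number, and the change is an at least 3.4-fold higher number from compound 3 to compound 4 (0.53 log units; beyond the scatter). Going by these compounds, the true size of this step stays unknown, and only its minimum can be read: the limit of > 10000 nM in this assay, at which 1 of the 4 values shown sits. Among the methylamino compounds, compound 1 gives 151 nM and compound 2, with a different group at this place, gives 38.6 nM, so a lower number with a single-ring group at this place does not carry over to the dimethylamino compounds shown here.

Open, on these data alone, is how 4-methoxyphenyl behaves when paired with the methylamino group. Also open, as far as these compounds go, is whether a free amino group or a pyrrolidine ring on the same ring atom would give a measurable value with this group.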